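Swapping the Aryl for a Benzyl on the Ring Nitrogen

The source may report more compounds than this note shows. Statements on the series, on what has been measured and on what is new or still open speak of the compounds shown alone.

Of the compounds shown here, three have been measured in a functional assay on Huh-7 cells (Homo sapiens) for antiproliferative activity, read by sulforhodamine B assay, with a stated time of 72 h; a lower number here means a stronger inhibitor, a higher number a weaker inhibitor. Compound 1 `Cc1cccc(COc2ccc(-c3cc(CN4CCN(Cc5ccc(C(F)(F)F)cc5)CC4)no3)cc2)c1` gives 5000 nM, compound 2 `N#Cc1ccc(COc2ccc(-c3cc(CN4CCN(Cc5ccc(C(F)(F)F)cc5)CC4)no3)cc2)cc1` gives 1000 nM, and compound 3 `N#Cc1cccc(COc2ccc(-c3cc(CN4CCN(c5ccc(C(F)(F)F)cc5)CC4)no3)cc2)c1` gives 2200 nM. Compound 3 therefore stands second highest of the three: its number is higher than that of compound 2 and lower than that of compound 1, and both gaps lie beyond the scatter. Among the compounds with values here, the only step measured between two compounds that differ in one place, a 5.0-fold lower number from compound 1 to compound 2 (0.70 log units; beyond the scatter), concerns the benzyl ether end of the shared core.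

Compound 4 `N#Cc1cccc(COc2ccc(-c3cc(CN4CCN(Cc5cccc(F)c5)CC4)no3)cc2)c1` alters a different end: 3-fluorobenzyl in place of 4-(trifluoromethyl)phenyl on an amine nitrogen in a ring. Within the data shown here, no measured step touches that position, and compounds 2 and 3, which differ there, differ elsewhere as well, so their two values show only that compound 2 has the lower number. With nothing to set a direction, compound 4 is expected to land near compound 3 in this assay. The expected step is a 1.1-fold lower number from compound 3 to compound 4 (0.04 log units; within the scatter), not beyond the scatter. Compound 4 is estimated at 2000 nM, with a range from 700 nM to 6000 nM.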

Compound 4, half-maximal inhibitory concentration: 2700 nM
Compound 4: middle estimate off by 1.4-fold (0.13 log units), on the low side; low and high end bracket the measured number.
By their numbers in this assay, from the lowest: compound 2; then compounds 3, 4 and 1 (each within the scatter of the next, the first and the last beyond it).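

Within the data shown here, this is the first measured step at the amine nitrogen in the six-membered ring. In this assay, 3-fluorobenzyl replaces 4-(trifluoromethyl)phenyl, and the result is a 1.2-fold higher number from compound 3 to compound 4 (0.09 log units; within the scatter), so the two compounds cannot be told apart. For this pair, then, replacing the aromatic group on that nitrogen with a benzyl group carrying a different fluorine substituent leaves no change that can be separated from the scatter, and nothing available here offers an explanation for that.

As far as these compounds go, this swap changes the link to the nitrogen and the substituent on the aromatic ring together, so their separate contributions remain open. Also open, from the compounds shown here alone, is what an amine or a carboxylic acid on that aromatic ring would do to the number.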